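Methyl to Fluoro: One Change on Compound 1

The source may hold more compounds than are shown below. What is called first, only, known or untested is meant among the compounds shown, and "the series" means these compounds.

Measured so far:
compound 1, `Cc1ccc(-c2nc(CNc3ccc(C(=O)NO)cc3)n(-c3ccccc3)n2)cc1`, 62.2%
compound 2, `COc1ccc(-n2nc(-c3ccccc3)nc2CNc2ccc(C(=O)NO)cc2)cc1`, 63.4%

Both compounds were tested in an assay on Sf9 cells for inhibition of protein deacetylase HDAC6 (Homo sapiens), read by fluorescence, with a stated time of 40 min, tested at 100 nM; a higher number here means more inhibition at the concentration tested (going by the name of the read-out), a lower number less inhibition. Compound 1 gives 62.2%, and compound 2 gives 63.4%. On these two numbers compound 1 stands as the lower entry, but its gap to compound 2 is within the scatter, so the two cannot be told apart. Among the measured compounds shown here, no pair of measured compounds differs in a single place, so nothing yet shows how a small change on this core shifts the read-out.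

Compound 3, `O=C(NO)c1ccc(NCc2nc(-c3ccc(F)cc3)nn2-c2ccccc2)cc1`, is unmeasured. It differs from compound 1 by fluoro in place of methyl on an aromatic carbon. For the measured compounds named here, with no measured step of this kind to lean on, the step of a number 2.2 percentage points lower from compound 1 to compound 3 (within the scatter) is expected to stay within the scatter, in either direction. Compound 3 is therefore expected to come out near 60%, between 45% and 75%.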

Compound 3, a percentage reported as inhibition, at one concentration (the size of the read-out at that concentration, not a potency): 70.9%
Compound 3: middle estimate off by 10.9 percentage points, on the low side, and the stated range covers the measured number.
By their numbers in this assay, from the lowest: compounds 1, 2 and 3 (each within the scatter of the next).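

Fluoro in place of methyl, or 4-methylphenyl to 4-fluorophenyl, gives the first step on this core in which only one place changes: in this assay it is a number 8.7 percentage points higher from compound 1 to compound 3 (within the scatter). This shows that on this aromatic carbon, para to a large group, one of these two small groups can replace the other without a change that can be told apart from the ordinary spread of repeated measurements. No measurement shown bears on what lies behind the size of this step.

From the compounds shown here alone, whether a different group at this same place, such as an amine or a carboxylic acid, would move the read-out beyond the scatter remains open. Going by these compounds, the read-out is also taken at one concentration and is not a potency, so how compound 1 and compound 3 compare in potency remains open too.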